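The source may report more compounds than this note shows. Statements on the series, on what has been measured and on what is new or still open speak of the compounds shown alone.

Compound 2 `COc1ccccc1-c1cc(C2CCN(C)C2)ccc1Cl`: 19 nM
Compound 3 `CNCc1ccc(Cl)c(-c2ccccc2OC)c1`: 1200 nM
Compound 1 `CCCN(CCC)Cc1ccc(Cl)c(-c2ccccc2OC)c1`: > 10000 nM, a limit of the assay

In an assay on isolated protein for binding affinity to 5-hydroxytryptamine receptor 1D (Homo sapiens) (on this read-out lower numbers stand for stronger inhibition and higher numbers for weaker inhibition), compound 2 gives 19 nM, the lowest of the two numbers here; the nearest number lies a 63-fold higher number from compound 2 to compound 3 (1.80 log units; beyond the scatter). The value of compound 1 in this assay is a limit, (the limit of > 10000 nM in this assay, at which 1 of the 3 values shown sits). Compound 4 `CCCCNCc1ccc(Cl)c(-c2ccccc2OC)c1` carries (butylamino)methyl in place of 1-methylpyrrolidin-3-yl on an aromatic carbon. For the measured compounds named here, two measured steps bear on this change: a 63-fold higher number from compound 2 to compound 3 (1.80 log units; beyond the scatter), where the ring gives way to (methylamino)methyl, and an at least 8.3-fold lower number from compound 1 to compound 3 (0.92 log units; beyond the scatter), where methylamino does better than dipropylamino. Compound 4 keeps the open chain and a secondary amine but with a butyl group, so a large rise is expected, a 130-fold higher number from compound 2 to compound 4 (2.12 log units; beyond the scatter), weaker than compound 3 yet short of the limit of compound 1. Compound 4 is estimated at 2500 nM, between 600 nM and 10000 nM.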

Compound 4, inhibition constant: 2000 nM
The estimate for compound 4 lay 1.3-fold (0.10 log units) above the measured number; the measured number falls inside the stated range.
By their numbers in this assay, from the lowest: compound 2; then compounds 3 and 4 (each within the scatter of the next). At a limit, above all of these: compound 1.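

In this assay, replacing the methyl of the open-chain secondary amine with butyl leaves the number within the scatter, a 1.7-fold higher number from compound 3 to compound 4 (0.22 log units; within the scatter), so these two chains are not told apart at this position. The ring keeps its large lead over the butyl chain, a 110-fold higher number from compound 2 to compound 4 (2.02 log units; beyond the scatter), with 1-methylpyrrolidin-3-yl on the aromatic carbon para to the chloro group. Compound 1 stands at a limit of the assay, so the step from dipropylamino to butylamino reads only as a bound, an at least 5.0-fold lower number from compound 1 to compound 4 (0.69 log units; beyond the scatter).

Still open, on these data alone, is how a primary amine or a dimethylamino group on the open chain would compare. Also open, as far as these compounds go, is whether a piperidine ring, or the pyrrolidine without its methyl, would match compound 2.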